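Cytotoxicity series: removing the aminomethyl piperidine leaves an aldehyde

The source may hold more compounds than are shown below. What is called first, only, known or untested is meant among the compounds shown, and "the series" means these compounds.

Measured compounds:
Compound 1 `COc1ccc(/C=C\c2cc(OC)c(OC)c(OC)c2)cc1OCc1ccc(CN2CC[C@H](C(=O)O)C2)cc1` in an ADME assay on HEK293 cells (Homo sapiens) for cytotoxicity, read by CCK-8 assay, with a stated time of 48 h (on this read-out higher numbers stand for weaker inhibition and lower numbers for stronger inhibition), gives > 50000 nM, a limit of the assay.
Compound 2 `COc1ccc(/C=C\c2cc(OC)c(OC)c(OC)c2)cc1OCc1ccc(CN2CCCC[C@H]2C(=O)O)cc1` in this assay gives > 50000 nM, a limit of the assay.
Compound 3 `COc1ccc(/C=C\c2cc(OC)c(OC)c(OC)c2)cc1OCc1ccc(CN2CCCCC2C(=O)NCCN)cc1` in this assay gives > 50000 nM, a limit of the assay.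

Compound 2 stands where every other measured compound stands: its value is a limit, and no number is known for it. The three measured steps, a step that the two limits leave unreadable from compound 1 to compound 2, a step that the two limits leave unreadable from compound 1 to compound 3 and a step that the two limits leave unreadable from compound 2 to compound 3, are all unreadable because of the limit of > 50000 nM in this assay, at which 3 of the 3 values shown sit. Nothing in the measured set therefore tells how large any change in this series can be in this assay.

The next compound is compound 4 `COc1ccc(/C=C\c2cc(OC)c(OC)c(OC)c2)cc1OCc1ccc(C=O)cc1`. It differs from compound 2 by formyl in place of (2-carboxypiperidin-1-yl)methyl on an aromatic carbon. For the measured compounds named here, no measured step covers a change of this kind, since all measured steps exchange one saturated nitrogen-containing ring for another while the aldehyde has none.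

With every measured compound sitting at the limit, the expectation for compound 4 can rest only on that: the step of a number no higher from compound 2 to compound 4 (the limit leaves the size open) is expected to stay within the scatter, and compound 4 is estimated at 50000 nM (range 10000 nM to 100000 nM), most probably reported again as a limit.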

Compound 4, half-maximal inhibitory concentration: 46000 nM
Beside the measured number, compound 4's estimate is 1.1-fold (0.04 log units) above it, within the range that was stated.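

In this assay compound 4 gives 46000 nM, the only reading so far that is a number and not a limit, and it is also the only compound shown with no saturated nitrogen-containing ring on this aromatic carbon, para to a large group. Exchanging (2-carboxypiperidin-1-yl)methyl for formyl is an at least 1.0-fold lower number from compound 2 to compound 4 (0.03 log units; that floor lies within the scatter), and exchanging (3-carboxypyrrolidin-1-yl)methyl for formyl is an at least 1.0-fold lower number from compound 1 to compound 4 (0.03 log units; that floor lies within the scatter), so these floors show no difference beyond the scatter, although the series now has a first measured point at this position. The true size of both steps stays unreadable because one end of each is not a number: the limit of > 50000 nM in this assay, at which 3 of the 4 values shown sit.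

Open, as far as these compounds go, is whether an aminomethyl group or a carboxylic acid set directly on this aromatic carbon, without a saturated ring, would also read as a number or return to a limit. Open too, from the compounds shown here alone, is whether the number belongs to the formyl itself or only to the loss of the ring, a question that a hydroxymethyl or a plain methyl group at the same place would address.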